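The source may hold more compounds than are shown below. What is called first, only, known or untested is meant among the compounds shown, and "the series" means these compounds.

The series rests on a shared core, seen in compound 1 `CNC(=O)N1CC1C#N`, which carries a methyl on the amide-type nitrogen. In a functional assay on L1210 cells (Mus musculus) for inhibition, read by MTT assay (on this read-out lower numbers stand for stronger inhibition and higher numbers for weaker inhibition), compound 1 gives 8700 nM. Compound 2 `N#CC1CN1C(=O)NC1CCCCC1` places a cyclohexyl there, and in this assay compound 2 gives 7400 nM. Compound 3 `CC(C)(C)NC(=O)N1CC1C#N` carries a tert-butyl at the same position; in this assay compound 3 gives 132000 nM, the highest of the three numbers, with compound 1 nearest and compound 2 furthest. For the measured compounds named here, the only single-place step measured so far is a 15-fold higher number from compound 1 to compound 3 (1.18 log units; beyond the scatter), a large rise in the number.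

Compound 4 `CCNC(=O)N1CC1C#N` is the next member: ethyl in place of tert-butyl on an amide-type nitrogen. The step from compound 1 to compound 3 bears directly on this change, since it shows that putting tert-butyl in place of methyl on that nitrogen raised the number sharply, and ethyl lies between methyl and tert-butyl, so most of that rise is expected to be undone. Because of a 15-fold higher number from compound 1 to compound 3 (1.18 log units; beyond the scatter), compound 4 is expected to fall well below compound 3 and to sit nearer compound 1, though perhaps somewhat above it. The expected step is an 11-fold lower number from compound 3 to compound 4 (1.04 log units; beyond the scatter). Compound 4 is therefore estimated at 12000 nM, within a range from 5000 nM to 40000 nM.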

Compound 4, half-maximal inhibitory concentration: 14000 nM
For compound 4 the middle estimate is 1.2-fold (0.07 log units) below the measured one, and the stated range covers the measured number.
By their numbers in this assay, from the lowest: compounds 2, 1 and 4 (each within the scatter of the next); then compound 3.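

In this assay, ethyl in place of tert-butyl on an amide-type nitrogen gives a 9.4-fold lower number from compound 3 to compound 4 (0.97 log units; beyond the scatter), so the high number of compound 3 does not carry over to the ethyl member. Ethyl in place of methyl gives a 1.6-fold higher number from compound 1 to compound 4 (0.21 log units; within the scatter), which means that compound 1 and compound 4 cannot be told apart on this read-out, and the extra carbon of the ethyl group makes no measurable difference at this position. Among these three compounds, which differ only in this group, the large step therefore belongs to tert-butyl alone, whereas the earlier compounds had shown only that tert-butyl stood apart from methyl, and nothing presented here explains why the numbers fall as they do.

The compounds shown leave open where the large rise sets in, since isopropyl and longer straight chains such as propyl or butyl on that nitrogen could read either like ethyl or like tert-butyl. They also leave open how a chain ending in an amine or a carboxylic acid would read at the same position.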